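The source may hold more compounds than are shown below. What is called first, only, known or untested is meant among the compounds shown, and "the series" means these compounds.

Measured compounds in the series:

- compound 1, `c1ccc2c(c1)CN[C@@H](CN(CCCCNCC1CCCCC1)[C@H]1CCCc3cccnc31)C2`: > 30000 nM in a functional assay on cells for agonist activity at C-X-C chemokine receptor type 4 (Homo sapiens), read by fluorescence and calcium flux, with a stated time of 90 s; a higher number here means that more compound is needed for the effect, a lower number that less compound is needed — a limit of the assay, not a number
- compound 2, `c1ccc2c(c1)CN[C@@H](CN(CCCCNC1CCOCC1)[C@H]1CCCc3cccnc31)C2`: > 30000 nM — a limit of the assay, not a number

Compound 2 stands at the upper limit of this assay; both values shown sit at the limit of > 30000 nM in this assay, at which 2 of the 2 values shown sit, so neither compound gives a readable number. The step from compound 1 to compound 2, a step that the two limits leave unreadable from compound 1 to compound 2, cannot be sized, as both ends are limits.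

Compound 3, `CC1(C)CCC(NCCCCN(C[C@H]2Cc3ccccc3CN2)[C@H]2CCCc3cccnc32)CC1`, differs from compound 2 by 4,4-dimethylcyclohexyl in place of oxan-4-yl on an amine nitrogen. Among the measured compounds shown here, the only measured step on the amine nitrogen, a step that the two limits leave unreadable from compound 1 to compound 2, is unreadable, and the cyclohexylmethyl of compound 1 and the oxan-4-yl of compound 2 both leave the series at the limit. For the measured compounds named here, no measured step gives a direction for this assay. The expected step from compound 2 to compound 3 is therefore a number no higher from compound 2 to compound 3 (the limit leaves the size open), none beyond the scatter, with a limit the most likely outcome. For compound 3 the estimate is 30000 nM, in the range 10000 nM to 100000 nM.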

Compound 3, half-maximal effective concentration: > 30000 nM
Compound 3: a limit, no number; the forecaster's own chance of this, stated with the estimate: 85%; the middle value sits exactly at the limit.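

In this assay compound 3 gives > 30000 nM, a limit and not a number. No step among compound 1, compound 2 and compound 3 can be read, as all three share one limit: the limit of > 30000 nM in this assay, at which 3 of the 3 values shown sit.

The compounds shown leave open which group on the amine nitrogen, if any, gives a readable number in this assay.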